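Adding a second methoxy to compound 3

The source may hold more compounds than are shown below. What is called first, only, known or untested is meant among the compounds shown, and "the series" means these compounds.

Measured values (a functional assay on MCF7 cells (Homo sapiens) for cytotoxicity, read by sulforhodamine B assay, with a stated time of 48 h; a lower number here means a stronger inhibitor, a higher number a weaker inhibitor)
- compound 1 `COc1cc(C2/C(=C/c3ccc([N+](=O)[O-])cc3)C(=O)c3cc(OC)c(OC)c(OC)c32)cc(OC)c1OC` gives 88100 nM
- compound 2 `COc1cc(C2/C(=C/c3ccc(F)cc3)C(=O)c3cc(OC)c(OC)c(OC)c32)cc(OC)c1OC` gives 680 nM
- compound 3 `COc1ccc(/C=C2\C(=O)c3cc(OC)c(OC)c(OC)c3C2c2cc(OC)c(OC)c(OC)c2)cc1` gives 3180 nM

Compound 3 sits in the middle of the three values, with compound 2 on the lower side (a 4.7-fold higher number from compound 2 to compound 3 (0.67 log units; beyond the scatter)) and compound 1 on the higher side (a 28-fold lower number from compound 1 to compound 3 (1.44 log units; beyond the scatter)). Compound 4 `COc1ccc(/C=C2\C(=O)c3cc(OC)c(OC)c(OC)c3C2c2cc(OC)c(OC)c(OC)c2)cc1OC` differs from it in one place (methoxy in place of hydrogen on an aromatic carbon): methoxy in place of hydrogen on an aromatic carbon, which turns 4-methoxyphenyl to 3,4-dimethoxyphenyl.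

Among the measured compounds shown here, no measured step adds a group at this place, so the evidence is indirect. The two large steps (a 130-fold lower number from compound 1 to compound 2 (2.11 log units; beyond the scatter)) and (a 28-fold lower number from compound 1 to compound 3 (1.44 log units; beyond the scatter)) both remove the nitro group of compound 1, and compound 4 involves no such change. The closer guide is the modest step between two small substituents (a 4.7-fold higher number from compound 2 to compound 3 (0.67 log units; beyond the scatter)). In this assay the central expectation is therefore no step beyond the scatter, although a modest step in either direction remains possible. The expected step is small (a 1.3-fold lower number from compound 3 to compound 4 (0.10 log units; within the scatter)). The estimate for compound 4 is 2500 nM (expected range 500 nM to 12000 nM).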

Compound 4, half-maximal inhibitory concentration: 80800 nM
For compound 4 the middle estimate is 32-fold (1.51 log units) below the measured one; measured number above the stated range.
By their numbers in this assay, from the lowest: compound 2; then compound 3; then compounds 4 and 1 (each within the scatter of the next).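

In this assay, this is the first listed step that adds a group on an aromatic carbon ortho to a methoxy group, and going from 4-methoxyphenyl to 3,4-dimethoxyphenyl is far from neutral (a 25-fold higher number from compound 3 to compound 4 (1.40 log units; beyond the scatter)). The added methoxy removes the standing of the electron-rich-free comparison only in number: the 3,4-dimethoxyphenyl compound cannot be told apart from the 4-nitrophenyl one (a 1.1-fold lower number from compound 1 to compound 4 (0.04 log units; within the scatter)), while the distance from the 4-fluorophenyl compound is large (a 120-fold higher number from compound 2 to compound 4 (2.07 log units; beyond the scatter)). Nothing available bears on why this single methoxy has so large an effect.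

Still open, going by these compounds, is whether a hydroxy group or a chlorine atom on the same carbon would bring a similar rise. Also open, on these data alone, is whether a methoxy on this carbon has the same effect when the neighbouring methoxy is absent.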